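This account rests on a few compounds, and the source may have more. Where it says the series, first, only, none or still open, it means among the compounds named here.

Measured so far in a functional assay on HL-60 cells (Homo sapiens) for antiproliferative activity, read by XTT assay, with a stated time of 72 h; on this read-out higher numbers stand for weaker inhibition and lower numbers for stronger inhibition:

compound 1 `C#Cc1cn([C@@H]2O[C@H](CO)[C@@H](O)[C@H]2O)c2ncnc(NC)c12`: 9060 nM
compound 2 `CNc1ncnc2c1c(-c1ccsc1)cn2[C@@H]1O[C@H](CO)[C@@H](O)[C@H]1O`: > 20000 nM
compound 3 `C#Cc1cn([C@@H]2O[C@H](CO)[C@@H](O)[C@H]2O)c2ncnc(SC)c12`: 50 nM

The value for compound 2 is a limit of the assay and not a number (the limit of > 20000 nM in this assay, at which 1 of the 3 values shown sits).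

Compound 2 differs from compound 1 by thiophen-3-yl in place of ethynyl on an aromatic carbon. This gave an at least 2.2-fold higher number from compound 1 to compound 2 (0.34 log units; beyond the scatter); since compound 2 sits at the limit, the true size of that step is open and may be larger.

Compound 3 differs from compound 1 by methylsulfanyl in place of methylamino on an aromatic carbon. The step here is a 180-fold lower number from compound 1 to compound 3 (2.26 log units; beyond the scatter), and compound 3 holds the lowest number of the two measured values.

Compound 4 `CSc1ncnc2c1c(-c1ccsc1)cn2[C@@H]1O[C@H](CO)[C@@H](O)[C@H]1O` is not yet measured. It differs from compound 3 by thiophen-3-yl in place of ethynyl on an aromatic carbon; the place description is word for word the same as for the pair compound 1 and compound 2, so this is the same change set onto the core of compound 3.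

Within the data shown here, from the one earlier instance, compound 4 is expected to give a higher number than compound 3, with a step of about an 8.0-fold higher number from compound 3 to compound 4 (0.90 log units; beyond the scatter) in this assay, resting on an at least 2.2-fold higher number from compound 1 to compound 2 (0.34 log units; beyond the scatter) and on the open-ended nature of that step. Compound 4 is therefore estimated at 400 nM in this assay, with a likely range from 100 nM to 3000 nM.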

Compound 4, half-maximal inhibitory concentration: 4590 nM
Compound 4: middle estimate off by 11-fold (1.06 log units), on the low side, and the stated range ends below it.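

In this assay, thiophen-3-yl in place of ethynyl on the core of compound 3 gives a 92-fold higher number from compound 3 to compound 4 (1.96 log units; beyond the scatter) and so keeps the direction seen on the core of compound 1, but the two steps can be compared only through a limit: the same change on two cores in this assay, an at least 2.2-fold higher number (0.34 log units; beyond the scatter) from compound 1 to compound 2 and a 92-fold higher number (1.96 log units; beyond the scatter) from compound 3 to compound 4; the limit leaves it open whether they differ.

Read the other way, methylsulfanyl in place of methylamino keeps its direction on the thiophen-3-yl core, with an at least 4.3-fold lower number from compound 2 to compound 4 (0.63 log units; beyond the scatter), and its size on the two cores likewise stays uncompared: the same change on two cores in this assay, a 180-fold lower number (2.26 log units; beyond the scatter) from compound 1 to compound 3 and an at least 4.3-fold lower number (0.63 log units; beyond the scatter) from compound 2 to compound 4; the limit leaves it open whether they differ.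

The value of compound 2 is a limit and not a number, so the pairs show that direction carries from one core to the other but not whether the size of either step does: the limit of > 20000 nM in this assay, at which 1 of the 4 values shown sits.

Still open, going by these compounds, is whether a phenyl ring or a propynyl group in place of ethynyl would follow the same direction on both cores. Also open, on these data alone, is whether methoxy or dimethylamino in place of methylsulfanyl would give a step in the same direction.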